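The source may report more compounds than this note shows. Statements on the series, on what has been measured and on what is new or still open speak of the compounds shown alone.

Measured so far, in a functional assay on HCT-116 cells (Homo sapiens) for cytotoxicity, read by MTT assay; a higher number here means a weaker inhibitor, a lower number a stronger inhibitor:

- compound 1 `CCn1cc(C(=O)Nc2ccccc2O)c(=O)c2cc(F)c(N3CCNC(C)C3)c(F)c21`: 5370 nM
- compound 2 `CCn1cc(C(=O)Nc2ccc(Cl)cn2)c(=O)c2cc(F)c(N3CCNC(C)C3)c(F)c21`: 3300 nM

Among the measured compounds shown here, compound 2 and compound 1 lie within the scatter of each other; the only measured step, a 1.6-fold lower number from compound 1 to compound 2 (0.21 log units; within the scatter), does not separate them, so compound 2 has no distinct standing among the two numbers.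

Compound 3 `CCn1cc(C(=O)Nc2ccc(C)c([N+](=O)[O-])c2)c(=O)c2cc(F)c(N3CCNC(C)C3)c(F)c21` has not yet been measured. It differs from compound 2 by 4-methyl-3-nitrophenyl in place of 5-chloropyridin-2-yl on an amide-type nitrogen. For the measured compounds named here, the one step that bears on this position is a 1.6-fold lower number from compound 1 to compound 2 (0.21 log units; within the scatter), where one aromatic ring on the amide-type nitrogen was exchanged for another without a change beyond the scatter. Nothing measured speaks for the 4-methyl-3-nitrophenyl group in particular. On that basis a further exchange of the ring at this position is expected to stay within the scatter, in no clear direction: the step of a 1.2-fold higher number from compound 2 to compound 3 (0.08 log units; within the scatter) is the estimate. Compound 3 is therefore expected at about 4000 nM in this assay, with a range from 1500 nM to 12000 nM.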

Compound 3, half-maximal inhibitory concentration: 11800 nM
The estimate for compound 3 lay 3.0-fold (0.47 log units) below the measured number; measured number inside the range.
By their numbers in this assay, from the lowest: compounds 2 and 1 (each within the scatter of the next); then compound 3.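

In this assay the ring on the amide-type nitrogen can shift the number: the steps of a 3.6-fold higher number from compound 2 to compound 3 (0.55 log units; beyond the scatter) and a 2.2-fold higher number from compound 1 to compound 3 (0.34 log units; beyond the scatter) are both beyond the scatter and both modest. The 4-methyl-3-nitrophenyl group therefore separates from both the 5-chloropyridin-2-yl and the 2-hydroxyphenyl groups, a difference the earlier step could not show, while compound 1 and compound 2 remain within the scatter of each other. Nothing measured here gives a reason for this separation.

Whether the methyl or the nitro group accounts for the shift remains open, as the two enter together in compound 3. A phenyl ring carrying only one of them, or an amine or a carboxylic acid in place of the nitro group, would test this on the same core.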